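A few compounds are considered here, and "the series" means these few. Any claim that something is new, unique, unknown or untested is made for them only; others in the source may bear on it.

In a functional assay on CCRF-CEM cells (Homo sapiens) for inhibition (on this read-out lower numbers stand for stronger inhibition and higher numbers for weaker inhibition), compound 1 `O=C1/C(=C/c2ccc(F)cc2)Cc2ccccc21` gives 42200 nM, and compound 2 `O=C1/C(=C/c2ccc(F)cc2)CCc2ccccc21` gives 33400 nM. Compound 3 `O=C1/C(=C/c2ccc(Br)cc2)CCc2ccccc21` yields no number, only a limit of > 500000 nM. Going by these compounds, its position is therefore known only as a bound, and the exact size of any step starting from it remains open.

Compound 4 `Cc1ccc(/C=C2\CCc3ccccc3C2=O)cc1` keeps the core of compound 3 and carries methyl in place of bromo on an aromatic carbon, para to a large group: methyl in place of bromo on an aromatic carbon. Among the measured compounds shown here, no measured compound carries this methyl, so the evidence is indirect. For the measured compounds named here, the one measured step at this place is the exchange of fluoro for bromo, which gave an at least 14-fold higher number from compound 2 to compound 3 (1.17 log units; beyond the scatter). That step was large and lies beyond the scatter. It shows that the group at this place can move the read-out strongly, and that bromo went with the weaker result. Removing bromo is therefore expected to give a large step towards stronger inhibition in this assay, landing nearer compound 2 at 33400 nM, though with wide uncertainty. The estimate amounts to an expected at least 7.1-fold lower number from compound 3 to compound 4 (0.85 log units; beyond the scatter). For compound 4, the estimated value is 70000 nM, with an expected range from 20000 nM to 300000 nM.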

Compound 4, half-maximal inhibitory concentration: 460000 nM
Beside the measured number, compound 4's estimate is 6.6-fold (0.82 log units) below it; the measured number lies above the stated range.
By their numbers in this assay, from the lowest: compounds 2 and 1 (each within the scatter of the next); then compound 4. At a limit, above all of these: compound 3.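

In this assay, methyl at this place, on an aromatic carbon para to a large group, does not bring the read-out back towards the fluoro compound: the change of fluoro to methyl gives a 14-fold higher number from compound 2 to compound 4 (1.14 log units; beyond the scatter). Among compounds 2, 3 and 4, which differ only at this place, the weak result is therefore not tied to bromo alone, and fluoro is the one group of the three that goes with a number near the stronger end. The comparison of methyl with bromo reads only as an at least 1.0-fold lower number from compound 3 to compound 4 (0.03 log units; that floor lies within the scatter), and as that floor lies within the scatter, it cannot be said whether the two groups differ, with compound 3 held only at a limit: the limit of > 500000 nM in this assay, at which 1 of the 4 values shown sits.

The compounds shown leave open whether the stronger result belongs to fluoro alone or would also appear with hydrogen, chloro, methoxy or an amine at this place. They also leave open whether methyl or bromo would weaken the result to the same extent on the core of compound 1, which appears here only with fluoro.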